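The source may report more compounds than this note shows. Statements on the series, on what has been measured and on what is new or still open speak of the compounds shown alone.

Measured compounds, with their values in a functional assay on HT-29 cells (Homo sapiens) for cytotoxicity, read by MTT assay, with a stated time of 24 h, tested at 1.6 ug/mL; a higher number here means a stronger effect of the compound at the concentration tested, a lower number a weaker effect:

compound 1 `Cn1c(-c2ccc(NC(=O)CSc3nc4cc(Cl)ccc4o3)cc2)nc(-c2ccccc2)c1-c1ccccc1`: 17.4%
compound 2 `Cn1c(-c2ccc(NC(=O)CSC3=NCCS3)cc2)nc(-c2ccccc2)c1-c1ccccc1`: 30.4%
compound 3 `CN(C)/C=C/N1CCN(CC(=O)Nc2ccc(-c3nc(-c4ccccc4)c(-c4ccccc4)n3C)cc2)CC1`: 8%

Compound 3 has the lowest of the three numbers in this assay. The gap to compound 1 is within the scatter, a number 9.4 percentage points lower from compound 1 to compound 3 (within the scatter), whereas the gap to compound 2 is beyond it, a number 22.4 percentage points lower from compound 2 to compound 3 (beyond the scatter). Within the data shown here, the only other step, a number 13 percentage points higher from compound 1 to compound 2 (beyond the scatter), was likewise modest.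

Compound 4 `Cn1c(-c2ccc(NC(=O)CN3CCN(c4ccccc4)CC3)cc2)nc(-c2ccccc2)c1-c1ccccc1` differs from compound 3 in one place: phenyl in place of 2-(dimethylamino)ethenyl on an amine nitrogen in a ring. Among the measured compounds shown here, no measured step alters this position; the measured steps all exchange the whole group on the saturated chain carbon bound to the carbonyl carbon, or the group on sulfur, and none of them moved this assay by more than a modest amount. The change from compound 3 to compound 4 is smaller in scope than any of those, so a step within the scatter, of uncertain direction, is expected: a number 4 percentage points higher from compound 3 to compound 4 (within the scatter).

Compound 4 is therefore estimated at 12% in this assay, with a range from 4% to 28%.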

Compound 4, a percentage reported as activity, at one concentration (the size of the read-out at that concentration, not a potency): 26%
The estimate for compound 4 lay 14 percentage points below the measured number, and the stated range covers the measured number.
By their numbers in this assay, from the lowest: compounds 3, 1, 4 and 2 (each within the scatter of the next, the first and the last beyond it).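

In this assay, the group on the amine nitrogen of the ring counts: a number 18 percentage points higher from compound 3 to compound 4 (beyond the scatter), with phenyl in place of 2-(dimethylamino)ethenyl, a change confined to the far end of the substituent on the saturated chain carbon. With phenyl there, 4-phenylpiperazin-1-yl cannot be separated from either group on the sulfur-linked compounds, as a number 4.4 percentage points lower from compound 2 to compound 4 (within the scatter) and a number 8.6 percentage points higher from compound 1 to compound 4 (within the scatter). Nothing available explains the step from 2-(dimethylamino)ethenyl to phenyl.

As far as these compounds go, whether the step depends on the aromatic ring itself or on the loss of 2-(dimethylamino)ethenyl remains open, and a methyl or benzyl group on the same nitrogen would help to separate the two. The read-out also comes from a single concentration, so it tells only of a stronger or weaker effect at that concentration.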